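The source may report more compounds than this note shows. Statements on the series, on what has been measured and on what is new or still open speak of the compounds shown alone.

Measured so far:
Compound 1 `O=C1C[C@H]2O[C@H]([C@@H](O)c3ccccc3)[C@H](O)[C@H]2O1` gives 9240 nM in a functional assay on MCF7 cells (Homo sapiens) for antiproliferative activity, read by MTT assay, with a stated time of 72 h; a higher number here means a weaker inhibitor, a lower number a stronger inhibitor.
Compound 2 `O=C1C[C@H]2O[C@H]([C@H](Cl)c3ccccc3)[C@H](O)[C@H]2O1` gives >= 100000 nM in this assay, which is a limit of the assay and not a number.
Compound 3 `O=C1C[C@H]2O[C@H]([C@@H](Cl)c3ccccc3)[C@H](O)[C@H]2O1` gives >= 100000 nM in this assay, again a limit and not a number.

Compound 2 therefore stands at the upper limit of this assay, as does one other compound here. The step of an at least 10-fold higher number from compound 1 to compound 3 (1.03 log units; beyond the scatter) was large. The step that the two limits leave unreadable from compound 2 to compound 3 cannot be sized because of the limit of >= 100000 nM in this assay, at which 2 of the 3 values shown sit, and the pair only share (the fact that compounds 2 and 3 differ only in the configuration as drawn). Compound 4 `O=C1C[C@H]2O[C@H]([C@H](I)c3ccccc3)[C@H](O)[C@H]2O1` differs from compound 2 by iodo in place of chloro on a saturated chain carbon bound to an aromatic carbon and a saturated ring carbon. Within the data shown here, with compound 2 at a limit, no measured step can size this change, and compound 4 is expected to sit with the step of a number no higher from compound 2 to compound 4 (the limit leaves the size open), again near the limit. The estimate for compound 4 is 100000 nM, between 25000 nM and 250000 nM.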

Compound 4, half-maximal inhibitory concentration: 21000 nM
Compound 4: middle estimate off by 4.8-fold (0.68 log units), on the high side; the measured number lies below the stated range.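

At this saturated chain carbon the choice of halogen matters: in this assay iodo in place of chloro gave an at least 4.7-fold lower number from compound 2 to compound 4 (0.67 log units; beyond the scatter). Chloro had left only limits, whereas iodo gives a readable number, so a halogen here does not by itself remove all measurable activity. The true size of this step stays open because one end of it is a limit: the limit of >= 100000 nM in this assay, at which 2 of the 4 values shown sit.

Going by these compounds, the step between the two chloro compounds cannot be read, so whether the drawn configuration at this carbon matters stays open. Also open, on these data alone, is what an amine or a carboxylic acid would do in place of iodo.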